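The source may hold more compounds than are shown below. What is called first, only, known or untested is meant among the compounds shown, and "the series" means these compounds.

In a functional assay on MCF7 cells (Homo sapiens) for inhibition, read by sulforhodamine B assay, with a stated time of 48 h (a lower number here means a stronger inhibitor, a higher number a weaker inhibitor), compound 1 `CCNC(=O)Nc1ccc(/C=C\c2cc(C)cc(C)c2)cc1` gives 17000 nM, compound 2 `CCNC(=O)Nc1ccc(/C=C\c2cc(OC)c(OC)c(OC)c2)cc1` gives 21000 nM and compound 3 `CCNC(=O)Nc1ccc(/C=C/c2cc(OC)c(OC)c(OC)c2)cc1` gives 17000 nM. Compound 2 thus lies within the scatter of both other compounds, and the three values show no separation. The next compound, compound 4 `COc1cc(/C=C\c2ccc(N3CCNC3=O)cc2)cc(OC)c1OC`, keeps the core of compound 2 but carries 2-oxoimidazolidin-1-yl in place of (ethylcarbamoyl)amino on an aromatic carbon, para to a large group: 2-oxoimidazolidin-1-yl in place of (ethylcarbamoyl)amino on an aromatic carbon. For the measured compounds named here, the one measured step, a 1.2-fold lower number from compound 2 to compound 3 (0.09 log units; within the scatter), lies within the scatter, and it comes with the fact that compounds 2 and 3 differ only in the configuration as drawn. It therefore leaves the (ethylcarbamoyl)amino group untouched and bears on this change only indirectly. Going by the values given here, no measured step tests this replacement, so no direction can be drawn from the data, and the expectation rests on the close values so far. In this assay, the expected 1.2-fold lower number from compound 2 to compound 4 (0.07 log units; within the scatter) is not estimated to go beyond the scatter. Compound 4 is expected at 18000 nM, with an estimated range from 5000 nM to 60000 nM.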

Compound 4, half-maximal inhibitory concentration: 2.6 nM
Estimate against measurement, compound 4: 6900-fold (3.84 log units) above; measured number outside the range, below it.
By their numbers in this assay, from the lowest: compound 4; then compounds 1, 3 and 2 (each within the scatter of the next).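

In this assay, the place on the aromatic carbon para to a large group proves decisive, since 2-oxoimidazolidin-1-yl in place of (ethylcarbamoyl)amino gives an 8100-fold lower number from compound 2 to compound 4 (3.91 log units; beyond the scatter). The earlier compounds shown here all carried (ethylcarbamoyl)amino and showed no separation, so they could not reveal this; the two groups hold the same heavy atoms, but the entering group closes them into a five-membered non-aromatic ring. Nothing measured here accounts for the size of this step.

The compounds shown leave open whether the ring itself matters or whether other groups at this place, such as a six-membered cyclic urea, a simple amine or a carboxylic acid, would give similar numbers. They also leave open how the 2-oxoimidazolidin-1-yl compound would behave with its double bond drawn E, or with 3,5-dimethyl substitution on the other ring.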